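The source may hold more compounds than are shown below. What is called first, only, known or untested is meant among the compounds shown, and "the series" means these compounds.

Measured in an ADME assay on the whole organism (Rattus norvegicus, strain Sprague-Dawley) for pharmacokinetics, read by LC-MS, with a stated time of 6 h, at a dose of 30 mg/kg by the oral route; on this read-out higher numbers stand for higher exposure at the dose given and lower numbers for lower exposure:
- Compound 1 `CC(=O)N1CCN(C(=O)CC2([C@H]3COC[C@@H](C4CC4)N3S(=O)(=O)c3ccc(F)cc3)CC2)CC1`: 3160 ng.h/mL
- Compound 2 `O=C(CC1([C@H]2CO[C@H]3CCC[C@H]3N2S(=O)(=O)c2ccc(Cl)cc2)CC1)N1CCC(CO)CC1`: 36 ng.h/mL

Compound 1 holds the higher of the two numbers, at 3160 ng.h/mL, and compound 2 gives 36 ng.h/mL. The gap between these two numbers lies beyond the scatter. Compound 3 `O=C(CC1([C@H]2COC[C@@H](C3CC3)N2S(=O)(=O)c2ccc(F)cc2)CC1)N1CCC(N2CCCCC2)CC1` keeps the core of compound 1 but has 4-(piperidin-1-yl)piperidin-1-yl in place of 4-acetylpiperazin-1-yl on a carbonyl carbon. For the measured compounds named here, no measured pair shows a change of this kind, so the expectation in this assay is a loose one. The expected step is a 4.5-fold lower number from compound 1 to compound 3 (0.65 log units; beyond the scatter), a fall beyond the scatter. Compound 3 is estimated at 700 ng.h/mL, within a range of 150 ng.h/mL to 3000 ng.h/mL.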

Compound 3, area under the concentration-time curve: 575 ng.h/mL
Compound 3: the middle estimate sits 1.2-fold (0.09 log units) above what was measured; measured number inside the range.
By their numbers in this assay, from the lowest: compound 2; then compound 3; then compound 1.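

In this assay, for the compounds shown here, the swap of 4-acetylpiperazin-1-yl for 4-(piperidin-1-yl)piperidin-1-yl on a carbonyl carbon gives a 5.5-fold lower number from compound 1 to compound 3 (0.74 log units; beyond the scatter) and is the first step here that changes one place alone. It shows that the group at this place can, with the rest of the core of compound 1 held fixed, move exposure beyond the scatter. Nothing measured here accounts for the fall. Which part of the exchanged group carries the step stays open, since this single step changes the whole group at once. Also open, on these data alone, is how a simple morpholine or an unsubstituted piperazine on the same carbonyl carbon would compare.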